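The source may hold more compounds than are shown below. What is called first, only, known or untested is meant among the compounds shown, and "the series" means these compounds.

Measured compounds in an assay on HEK293 cells for positive allosteric modulation of metabotropic glutamate receptor 5 (Homo sapiens), read by FLIPR, with a stated time of 1 h; a lower number here means that less compound is needed, a higher number that more compound is needed for the effect:
Compound 1, `CN1CCc2nc(C#Cc3ccccc3)sc2C1`, gives 34 nM.
Compound 2, `O=C(C1CC1)N1CCc2nc(C#Cc3ccccc3)sc2C1`, gives only an assay limit, > 10000 nM.
Compound 3, `COC1CC(C(=O)N2CCc3nc(C#Cc4ccccc4)sc3C2)C1`, gives 640 nM.

Compound 3 holds the higher of the two numbers in this assay; the step from the methyl compound is a 19-fold higher number from compound 1 to compound 3 (1.27 log units; beyond the scatter). Compound 4, `O=C(C1CCCCC1)N1CCc2nc(C#Cc3ccccc3)sc2C1`, differs from compound 3 by cyclohexyl in place of 3-methoxycyclobutyl on a carbonyl carbon. Among the measured compounds shown here, the one measured step at the carbonyl carbon is an at least 15-fold lower number from compound 2 to compound 3 (1.19 log units; beyond the scatter), in which the cyclopropyl amide sits at the limit of > 10000 nM in this assay, at which 1 of the 3 values shown sits, and only the 3-methoxycyclobutyl amide returns a number; both amides stand far from compound 1, as an at least 290-fold higher number from compound 1 to compound 2 (2.46 log units; beyond the scatter) shows. A higher number is expected for compound 4 in this assay, with a real chance of a limit. Compound 4 is estimated at 3000 nM, range 500 nM to 20000 nM, an expected step of a 4.7-fold higher number from compound 3 to compound 4 (0.67 log units; beyond the scatter).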

Compound 4, half-maximal effective concentration: 167 nM
Compound 4: middle estimate off by 18-fold (1.25 log units), on the high side; the whole stated range lies above it.
By their numbers in this assay, from the lowest: compound 1; then compound 4; then compound 3. At a limit, above all of these: compound 2.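

At the carbonyl carbon in this assay, cyclohexyl gives the lowest number among the three amides, with a 3.8-fold lower number from compound 3 to compound 4 (0.58 log units; beyond the scatter), so no oxygen in this group is needed for a measurable result. Compound 2 sits at a limit, and the gap to the cyclohexyl amide is wider: an at least 59-fold lower number from compound 2 to compound 4 (1.77 log units; beyond the scatter). Neither measurable amide comes close to the methyl compound, and the cyclohexyl amide still shows a 4.9-fold higher number from compound 1 to compound 4 (0.69 log units; beyond the scatter).

Unsubstituted cyclobutyl, cyclopentyl and a longer open chain remain open at this carbonyl carbon. Ring size and the methoxy oxygen therefore cannot be separated in the change from 3-methoxycyclobutyl to cyclohexyl.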